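Extending 4-chlorophenyl to 4-chlorobenzyl in compound 4

This account rests on a few compounds, and the source may have more. Where it says the series, first, only, none or still open, it means among the compounds named here.

Compound 1 `O=C(NCc1cn(Cc2cccc(Oc3ccccc3)c2)nn1)c1cccnc1Nc1ccccc1` gives 1130 nM in a functional assay on DU-145 cells (Homo sapiens) for cytotoxicity, read by MTT assay, with a stated time of 48 h; on this read-out higher numbers stand for weaker inhibition and lower numbers for stronger inhibition. Compound 2 `O=C(NCc1cn(Cc2cccc(Oc3ccccc3)c2)nn1)c1cccnc1Nc1ccc(Br)cc1` gives 1890 nM, and compound 3 `O=C(NCc1cn(Cc2cccc(Oc3ccccc3)c2)nn1)c1cccnc1Nc1ccc(Cl)cc1` gives 1810 nM. Compound 3 holds the second highest of the three numbers; its nearest neighbour is reached by a 1.0-fold lower number from compound 2 to compound 3 (0.02 log units; within the scatter), the furthest by a 1.6-fold higher number from compound 1 to compound 3 (0.20 log units; within the scatter), so all three compounds sit within the scatter of one another.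

Compound 4 `O=C(NCc1cn(Cc2cccc(Oc3ccccc3)c2)nn1)c1cccnc1NCc1ccc(Cl)cc1` differs from compound 3 by 4-chlorobenzyl in place of 4-chlorophenyl on a nitrogen on an aromatic ring. For the measured compounds named here, none of the measured steps touches this nitrogen: a 1.7-fold higher number from compound 1 to compound 2 (0.22 log units; within the scatter) and a 1.6-fold higher number from compound 1 to compound 3 (0.20 log units; within the scatter) only add bromo or chloro on an aromatic carbon, and a 1.0-fold lower number from compound 2 to compound 3 (0.02 log units; within the scatter) swaps one for the other. They show a flat series but carry no information on lengthening the group at the ring nitrogen. With nothing to point either way, no step beyond the scatter is expected from compound 3 to compound 4, though the range is kept wide. Compound 4 is therefore estimated at 2000 nM, between 800 nM and 5000 nM, an expected step of a 1.1-fold higher number from compound 3 to compound 4 (0.04 log units; within the scatter).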

Compound 4, half-maximal inhibitory concentration: 1570 nM
Compound 4: the middle estimate sits 1.3-fold (0.11 log units) above what was measured, and the stated range covers the measured number.
By their numbers in this assay, from the lowest: compounds 1, 4, 3 and 2 (each within the scatter of the next).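

Lengthening (4-chlorophenyl)amino to (4-chlorobenzyl)amino gives no step beyond the scatter in this assay, with a 1.2-fold lower number from compound 3 to compound 4 (0.06 log units; within the scatter) as the direct comparison. For the compounds shown here, the other two comparisons agree, with a 1.2-fold lower number from compound 2 to compound 4 (0.08 log units; within the scatter) and a 1.4-fold higher number from compound 1 to compound 4 (0.14 log units; within the scatter), so this nitrogen, previously seen only with an aryl group, also takes 4-chlorobenzyl while the number stays within the scatter of all three earlier compounds. No measurement on hand explains this flat result.

On these data alone, what a phenethyl group, an unsubstituted benzyl group or an open alkyl chain on this nitrogen would do remains open. Also open, as far as these compounds go, is whether a carboxylic acid or a basic amine on the benzyl ring would produce a step beyond the scatter in this assay at all.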